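Lengthening and Methylating the Amine Chain of Compound 3

The compounds below may be only part of what the source reports. "The series", "measured", "known", "first", "only" and "open" are said of these compounds alone.

In a functional assay on HT cells (Homo sapiens) for antiproliferative activity, read by fluorescence, with a stated time of 72 h (a lower number here means a stronger inhibitor of growth, a higher number a weaker inhibitor of growth), three compounds built on a shared core have been measured. Compound 1 `CC(C)c1n[nH]c2c(NCc3ccc(-c4ccccn4)cc3)nc(SCC(N)CN)nc12` gives 480 nM, compound 2 `CC(C)c1n[nH]c2c(NCc3ccc(-c4ccccn4)cc3)nc(SCC(O)CN)nc12` gives 55 nM, and compound 3 `CC(C)c1n[nH]c2c(NCc3ccc(-c4ccccn4)cc3)nc(SCCN)nc12` gives 22 nM, the lowest of the three numbers. Compound 4 `CC(C)c1n[nH]c2c(NCc3ccc(-c4ccccn4)cc3)nc(SCCCN(C)C)nc12` carries (dimethylamino)methyl in place of amino on a saturated chain carbon, two bonds along the chain from a sulfur.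

The measured steps all concern this same chain. The large one is a 22-fold lower number from compound 1 to compound 3 (1.34 log units; beyond the scatter), and the smaller ones are an 8.7-fold lower number from compound 1 to compound 2 (0.94 log units; beyond the scatter) and a 2.5-fold lower number from compound 2 to compound 3 (0.40 log units; beyond the scatter). In this small set, both compounds with a further group on the chain show higher numbers than compound 3 does. None of these steps lengthens the chain or adds methyl groups to its amine, so they offer only indirect guidance. A modest move to a higher number is therefore expected, a 2.0-fold higher number from compound 3 to compound 4 (0.31 log units; beyond the scatter). Compound 4 is estimated at 45 nM, with an expected range from 15 nM to 140 nM.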

Compound 4, concentration for 50% growth inhibition: 105 nM
For compound 4 the middle estimate is 2.3-fold (0.37 log units) below the measured one, within the range that was stated.
By their numbers in this assay, from the lowest: compound 3; then compounds 2 and 4 (each within the scatter of the next); then compound 1.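

In this assay, the change from (2-aminoethyl)sulfanyl to (3-(dimethylamino)propyl)sulfanyl gives a 4.8-fold higher number from compound 3 to compound 4 (0.68 log units; beyond the scatter), so this position also responds to a change in chain length and amine substitution, not only to a further group on the chain. The unbranched chain of compound 4 gives no clear gain over the branched hydroxy chain, with a 1.9-fold higher number from compound 2 to compound 4 (0.28 log units; within the scatter), a step within the scatter, yet it still compares well with the diamino chain, with a 4.6-fold lower number from compound 1 to compound 4 (0.66 log units; beyond the scatter). No evidence is available to explain these differences.

The step changes chain length and amine methylation together, so their separate contributions remain unresolved. A (3-aminopropyl)sulfanyl chain or a (2-(dimethylamino)ethyl)sulfanyl chain would separate the two, and a (2-(methylamino)ethyl)sulfanyl chain would test a single methyl group on the amine.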